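Isobutyl for Isopropyl: Expected Cytotoxicity of Compound 3

The source may report more compounds than this note shows. Statements on the series, on what has been measured and on what is new or still open speak of the compounds shown alone.

Measured so far in an ADME assay on cells (Homo sapiens) for cytotoxicity, read by polymerase chain reaction, with a stated time of 3 days; on this read-out lower numbers stand for higher toxicity in this test and higher numbers for lower toxicity in this test:
Compound 1 `CNc1nc(C)c(-c2nc3ccccc3s2)c(N[C@@H]2C[C@H](CO)[C@@H](O)[C@H]2O)n1` gives > 25000 nM, a limit of the assay rather than a number.
Compound 2 `Cc1nc(NC(C)C)nc(N[C@@H]2C[C@H](CO)[C@@H](O)[C@H]2O)c1-c1nc2ccccc2s1` gives 13000 nM.

Compound 2 therefore holds the only number shown in this assay; the other value is a limit, as the line the limit of > 25000 nM in this assay, at which 1 of the 2 values shown sits, records. Going by the values given here, the one measured step, an at least 1.9-fold lower number from compound 1 to compound 2 (0.28 log units; that floor lies within the scatter), exchanges methyl for isopropyl on the same nitrogen and, with its floor inside the scatter, sets no clear direction. Compound 3 `Cc1nc(NCC(C)C)nc(N[C@@H]2C[C@H](CO)[C@@H](O)[C@H]2O)c1-c1nc2ccccc2s1` differs from compound 2 by isobutyl in place of isopropyl on a nitrogen on an aromatic ring. Both alkylamines concerned are small and uncharged, and the step already seen along this nitrogen did not move beyond the scatter, so no step beyond the scatter is expected from compound 2 to compound 3; the estimated step is a 1.1-fold lower number from compound 2 to compound 3 (0.03 log units; within the scatter). Compound 3 is estimated at 12000 nM in this assay, within a range of 5000 nM to 28000 nM.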

Compound 3, half-maximal cytotoxic concentration: 10000 nM
Beside the measured number, compound 3's estimate is 1.2-fold (0.08 log units) above it, and the stated range covers the measured number.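

In this assay, the exchange of isopropyl for isobutyl on the nitrogen on an aromatic ring gives a 1.3-fold lower number from compound 2 to compound 3 (0.11 log units; within the scatter), so compound 2 and compound 3 cannot be told apart, and the two branched alkyl groups read alike at this position. Measured against the methyl group, however, isobutyl gives this position its first step beyond the scatter, an at least 2.5-fold lower number from compound 1 to compound 3 (0.39 log units; beyond the scatter), which the isopropyl step had not shown. The value of compound 1 is a limit and not a number, so this step gives only a floor, and its true size stays unknown: the limit of > 25000 nM in this assay, at which 1 of the 3 values shown sits.

The compounds shown leave open whether a longer chain, such as n-hexyl, on this nitrogen would go further in the same direction. They also leave open how a carboxylic acid or an amine at the end of such a chain would read.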